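A few compounds are considered here, and "the series" means these few. Any claim that something is new, unique, unknown or untested is made for them only; others in the source may bear on it.

Compound 1 `N#C/C(=C\c1ccccc1OS(=O)(=O)c1ccccc1[N+](=O)[O-])C(=O)Nc1nnc(Cc2ccc(F)cc2)s1` gives 35% in a functional assay on HL-60 cells (Homo sapiens) for inhibition, read by CCK-8 assay, with a stated time of 48 h, tested at 20 uM; on this read-out lower numbers stand for less inhibition of growth and higher numbers for more inhibition of growth at the one concentration tested. Compound 2 `N#C/C(=C\c1ccccc1OS(=O)(=O)c1ccc(F)cc1)C(=O)Nc1nnc(Cc2ccc(F)cc2)s1` gives 13% in this assay, and the step of a number 22 percentage points lower from compound 1 to compound 2 (beyond the scatter) accompanies the change (4-fluorophenyl in place of 2-nitrophenyl on a sulfonyl sulfur). Compound 3 `N#C/C(=C\c1ccccc1OS(=O)(=O)c1ccccc1[N+](=O)[O-])C(=O)Nc1nnc(Cc2cccc(F)c2)s1` gives 23% in this assay, with the step of a number 12 percentage points lower from compound 1 to compound 3 (beyond the scatter). The values of compound 2 and compound 3 lie within the usual scatter of each other.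

Compound 4 `N#C/C(=C\c1ccccc1OS(=O)(=O)c1ccc(F)cc1)C(=O)Nc1nnc(Cc2cccc(F)c2)s1` awaits measurement. It differs from compound 3 by 4-fluorophenyl in place of 2-nitrophenyl on a sulfonyl sulfur; this is the same change as from compound 1 to compound 2, at a place described in the same words, and it made a step of a number 22 percentage points lower from compound 1 to compound 2 (beyond the scatter). The cores of the two pairs differ by 3-fluorophenyl in place of 4-fluorophenyl on a saturated chain carbon bound to an aromatic carbon. Because that first instance gave the step of a number 22 percentage points lower from compound 1 to compound 2 (beyond the scatter) and compound 3 starts at 23%, a step of similar size is expected, a number 18 percentage points lower from compound 3 to compound 4 (beyond the scatter), though the lower start leaves less room to fall. Compound 4 is therefore expected to show about 5% in this assay, between -8% and 18%.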

Compound 4, percent growth inhibition at one concentration: 22%
Compound 4: middle estimate off by 17 percentage points, on the low side; measured number outside the range, above it.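

In this assay, 4-fluorophenyl in place of 2-nitrophenyl on a sulfonyl sulfur did not carry over from the core of compound 1 to the core of compound 3, giving a number 1 percentage points lower from compound 3 to compound 4 (within the scatter), and the two steps differ: the same change on two cores in this assay, a number 22 percentage points lower (beyond the scatter) from compound 1 to compound 2 and a number 1 percentage points lower (within the scatter) from compound 3 to compound 4, 21 percentage points apart, beyond the scatter of two such steps. The move from 4-fluorophenyl to 3-fluorophenyl on the saturated chain carbon likewise depended on the group on the sulfonyl sulfur, giving a number 9 percentage points higher from compound 2 to compound 4 (within the scatter), and these two steps also differ: the same change on two cores in this assay, a number 12 percentage points lower (beyond the scatter) from compound 1 to compound 3 and a number 9 percentage points higher (within the scatter) from compound 2 to compound 4, 21 percentage points apart, beyond the scatter of two such steps. The two changes therefore do not act independently across these four compounds, but this does not explain the dependence or show how either change would behave on another core.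

On these data alone, it remains open how a methyl group or a pyridine ring on the sulfonyl sulfur would read on these cores. Also open, as far as these compounds go, is what a chlorophenyl group on the saturated chain carbon would give.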